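Adding a Third Methoxy Group to Compound 2

This account rests on a few compounds, and the source may have more. Where it says the series, first, only, none or still open, it means among the compounds named here.

Compound 1 `CCOC(=O)[C@H](CCC(=O)O)NC(=O)c1ccc(CNc2nc3cc(N)cc(N)c3nc2-c2ccccc2)cc1` gives 91200 nM in a functional assay on HOP-92 cells (Homo sapiens) for inhibition, read by sulforhodamine B assay, with a stated time of 48 h; a higher number here means a weaker inhibitor of growth, a lower number a stronger inhibitor of growth. Compound 2 `COc1ccc(CNc2nc3cc(N)cc(N)c3nc2-c2ccccc2)cc1OC` gives 13500 nM in this assay. Compound 3 `CCOC(=O)[C@H](CCC(=O)O)NC(=O)c1ccc(Sc2nc3cc(N)cc(N)c3nc2-c2ccccc2)cc1` gives 3800 nM in this assay.

Among these three numbers compound 2 stands second highest: compound 3 gives a lower number and compound 1 a higher one, and both gaps lie beyond the usual scatter. Compound 4 `COc1cc(CNc2nc3cc(N)cc(N)c3nc2-c2ccccc2)cc(OC)c1OC` differs from compound 2 in one place: methoxy in place of hydrogen on an aromatic carbon. For the measured compounds named here, no measured pair shows this change, so the expected step from compound 2 to compound 4 is none beyond the scatter, in either direction. Compound 4 is therefore estimated at 12000 nM, with a range from 4000 nM to 40000 nM. The expected step is a 1.1-fold lower number from compound 2 to compound 4 (0.05 log units; within the scatter).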

Compound 4, concentration for 50% growth inhibition: 1200 nM
For compound 4 the middle estimate is 10-fold (1.00 log units) above the measured one; measured number outside the range, below it.
By their numbers in this assay, from the lowest: compound 4; then compound 3; then compound 2; then compound 1.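

Methoxy in place of hydrogen on this aromatic carbon, ortho to a methoxy group and meta to a large group, gives in this assay an 11-fold lower number from compound 2 to compound 4 (1.05 log units; beyond the scatter) and so has a large effect on the number. For the compounds shown here, this is the first pair here that differs in one place, so the earlier compounds could not show that this carbon responds to substitution at all. Nothing available accounts for the size of this step.

On these data alone, whether methoxy itself is needed stays open, since a hydroxyl, an amine or an ethoxy group on this carbon would test that. Also open, as far as these compounds go, is whether the same change would lower the number with the glutamate ethyl ester side chain of compound 1.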